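This account rests on a few compounds, and the source may have more. Where it says the series, first, only, none or still open, it means among the compounds named here.

The measured compounds:
Compound 1 `O=C(c1ccccc1)c1ccc(NC(=O)c2cc(Cl)ccc2O)cc1` gives 48000 nM in an ADME assay on MONO-MAC-6 cells (Homo sapiens) for cytotoxicity, read by MTT assay, with a stated time of 16 h; on this read-out lower numbers stand for stronger inhibition and higher numbers for weaker inhibition.
Compound 2 `O=C(Oc1ccc(Cl)cc1C(=O)Nc1ccc(C(F)(F)F)cc1)c1cnc(Cl)cn1` gives 1100 nM in this assay.
Compound 3 `O=C(NCCCCl)Oc1ccc(Cl)cc1C(=O)Nc1ccc(C(F)(F)F)cc1` gives 8800 nM in this assay.

Compound 3 stands second highest of the three numbers: compound 1 sits above it and compound 2 below it, both gaps beyond the scatter. Within the data shown here, the only single-point step among the measured compounds is an 8.0-fold higher number from compound 2 to compound 3 (0.90 log units; beyond the scatter), which concerns the group on the carbonyl carbon and not the substituent on the aniline ring. Compound 4 `O=C(NCCCCl)Oc1ccc(Cl)cc1C(=O)Nc1ccc(C(=O)c2ccccc2)cc1` differs from compound 3 by benzoyl in place of trifluoromethyl on an aromatic carbon, para to a large group. Among the measured compounds shown here, no measured step bears directly on this change. Compound 1 carries the same benzoyl group and gives the highest number, but it also differs from compound 3 in a second place, so its value cannot be assigned to the benzoyl alone. The expectation for compound 4 in this assay is therefore a small rise, a 1.9-fold higher number from compound 3 to compound 4 (0.29 log units; within the scatter), held with wide uncertainty. Compound 4 is estimated at 17000 nM, between 5000 nM and 60000 nM.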

Compound 4, half-maximal inhibitory concentration: 16100 nM
For compound 4 the middle estimate is 1.1-fold (0.02 log units) above the measured one, within the range that was stated.
By their numbers in this assay, from the lowest: compound 2; then compounds 3 and 4 (each within the scatter of the next); then compound 1.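

In this assay, benzoyl in place of trifluoromethyl on an aromatic carbon, para to a large group, gives a 1.8-fold higher number from compound 3 to compound 4 (0.26 log units; within the scatter), so this position takes the added six-membered aromatic ring and hydrogen-bond acceptor with no change that can be told from the scatter. Among these compounds, with benzoyl held in place, the other step gives a 3.0-fold lower number from compound 1 to compound 4 (0.47 log units; beyond the scatter), which lies beyond the scatter and is the first reading of (3-chloropropyl)carbamoyl in place of hydrogen on the oxygen on the aromatic ring. Nothing measured here offers an explanation for either step.

Going by these compounds, whether other groups on this aromatic carbon, such as an amine or a carboxylic acid, would also stay within the scatter of compound 3 remains open. So does whether a longer chain in place of the 3-chloropropyl group would shift the number.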